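Notes on glucoside removal across two conjugate linkers

A few compounds are considered here, and "the series" means these few. Any claim that something is new, unique, unknown or untested is made for them only; others in the source may bear on it.

Measured so far, in a functional assay on HCT-116 cells (Homo sapiens) for cytotoxicity, read by sulforhodamine B assay, with a stated time of 48 h; on this read-out lower numbers stand for stronger inhibition and higher numbers for weaker inhibition:
compound 1, `O=C(CCCSSCCOCCOCCOc1cc(O)c(C(=O)CCc2ccc(O)cc2)c(O[C@@H]2O[C@H](CO)[C@@H](O)[C@H](O)[C@H]2O)c1)OCn1cc(F)c(=O)[nH]c1=O`, gives 54900 nM
compound 2, `O=C(CCCSSCCOCCOCCOc1cc(O)c(C(=O)CCc2ccc(O)cc2)c(O)c1)OCn1cc(F)c(=O)[nH]c1=O`, gives 21200 nM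
compound 3, `O=C(CCCc1cn(CCOCCOCCOc2cc(O)c(C(=O)CCc3ccc(O)cc3)c(O[C@@H]3O[C@H](CO)[C@@H](O)[C@H](O)[C@H]3O)c2)nn1)OCn1cc(F)c(=O)[nH]c1=O`, gives > 100000 nM

Compound 1 and compound 2 share a core and differ in one place: hydrogen in place of 3,4,5-trihydroxy-6-(hydroxymethyl)oxan-2-yl on an oxygen on an aromatic ring. That change produced a 2.6-fold lower number from compound 1 to compound 2 (0.41 log units; beyond the scatter).

Compound 3 carries the same sugar on a different core. How the core of compound 3 differs from the core of compound 1 is not broken down here. In this assay compound 3 gives only a limit, > 100000 nM. This is the limit of > 100000 nM in this assay, at which 1 of the 3 values shown sits, so no number stands for compound 3, only the statement that the true value lies beyond the range measured.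

Compound 4, `O=C(CCCc1cn(CCOCCOCCOc2cc(O)c(C(=O)CCc3ccc(O)cc3)c(O)c2)nn1)OCn1cc(F)c(=O)[nH]c1=O`, is the not yet measured partner of compound 3. It differs from compound 3 by hydrogen in place of 3,4,5-trihydroxy-6-(hydroxymethyl)oxan-2-yl on an oxygen on an aromatic ring, which is the same change as that from compound 1 to compound 2, at the same kind of place. On the disulfide-linked core that change read as a modest step beyond the scatter, a 2.6-fold lower number from compound 1 to compound 2 (0.41 log units; beyond the scatter). Since the starting point on the second core is a limit rather than a number, the expected result for compound 4 is wide: an estimated step of an at least 1.6-fold lower number from compound 3 to compound 4 (0.22 log units; that floor lies within the scatter), with a fair chance that compound 4 also returns only a limit. Compound 4 is expected at about 60000 nM, the estimate running from 25000 nM to 150000 nM.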

Compound 4, half-maximal inhibitory concentration: > 100000 nM
Compound 4: only a limit was reported; the forecaster's own chance of this, stated with the estimate: 40%; middle value at least 1.6-fold (0.22 log units) from the limit.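

Compound 3 and compound 4 each return only a limit in this assay, so no step between them can be read: the limit of > 100000 nM in this assay, at which 2 of the 4 values shown sit.

The compounds shown leave open how far beyond that limit either compound lies, and whether hydrogen in place of 3,4,5-trihydroxy-6-(hydroxymethyl)oxan-2-yl changes the number on the core of compound 3 as it does on the core of compound 1.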